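Replacing methylsulfonyl with trifluoromethyl at the ortho position

The compounds below may be only part of what the source reports. "The series", "measured", "known", "first", "only" and "open" are said of these compounds alone.

Of the compounds shown here, three sharing one core have been measured in a functional assay on HEK293 cells for antagonist activity at transient receptor potential cation channel subfamily V member 1 (Rattus norvegicus), read by calcium flux; on this read-out higher numbers stand for weaker inhibition and lower numbers for stronger inhibition. Compound 1 `Cc1cccc(C)c1Nc1nc2c(Nc3ccc(C(F)(F)F)cc3)ncnc2s1` gives 6 nM, compound 2 `CSc1ccccc1Nc1nc2c(Nc3ccc(C(F)(F)F)cc3)ncnc2s1` gives 26 nM, and compound 3 `CS(=O)(=O)c1ccccc1Nc1nc2c(Nc3ccc(C(F)(F)F)cc3)ncnc2s1` gives 221 nM. Compound 3 thus shows the highest number of the three: the step of an 8.5-fold higher number from compound 2 to compound 3 (0.93 log units; beyond the scatter) and the step of a 37-fold higher number from compound 1 to compound 3 (1.57 log units; beyond the scatter) both lie beyond the scatter, while a 4.3-fold higher number from compound 1 to compound 2 (0.64 log units; beyond the scatter) is a smaller, modest step.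

Compound 4 `FC(F)(F)c1ccc(Nc2ncnc3sc(Nc4ccccc4C(F)(F)F)nc23)cc1` has not yet been measured. It differs from compound 3 in one place: trifluoromethyl in place of methylsulfonyl on an aromatic carbon. The entering trifluoromethyl, like the methylsulfanyl of compound 2 and unlike the leaving methylsulfonyl, carries no hydrogen-bond acceptors. The two steps that bear on this change are an 8.5-fold higher number from compound 2 to compound 3 (0.93 log units; beyond the scatter) and a 37-fold higher number from compound 1 to compound 3 (1.57 log units; beyond the scatter), both of which show that removing the methylsulfonyl from this position is accompanied by a clearly lower number. A step of similar direction is therefore expected here, of modest to large size, landing compound 4 in the region between compound 2 and compound 1. The estimate for compound 4 in this assay is 20 nM, with a range from 6 nM to 70 nM, which would mean an expected step of an 11-fold lower number from compound 3 to compound 4 (1.04 log units; beyond the scatter).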

Compound 4, half-maximal inhibitory concentration: 37 nM
Compound 4: the middle estimate sits 1.9-fold (0.27 log units) below what was measured, within the range that was stated.
By their numbers in this assay, from the lowest: compound 1; then compounds 2 and 4 (each within the scatter of the next); then compound 3.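

In this assay, the lower number on leaving methylsulfonyl is not special to the methylsulfanyl of compound 2: trifluoromethyl, a second group with no hydrogen-bond acceptors, gives a 6.0-fold lower number from compound 3 to compound 4 (0.78 log units; beyond the scatter), and exchanging the two groups gives a 1.4-fold higher number from compound 2 to compound 4 (0.15 log units; within the scatter), so this read-out does not separate them. Among the three groups at this position on the single-substituted phenyl, methylsulfonyl, the only one counted with hydrogen-bond acceptors, thus stands apart, yet the 2,6-dimethylphenyl of compound 1 still differs clearly from the new group, with a 6.2-fold higher number from compound 1 to compound 4 (0.79 log units; beyond the scatter). Nothing shown here gives a measured reason for any of these differences.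

As far as these compounds go, it remains open whether the link with hydrogen-bond acceptors holds beyond these compounds, since a methoxy group, a nitrile or an amine at the same position would test it with no sulfur present. Also open, from the compounds shown here alone, is whether a single methyl, as in 2-methylphenyl, would read like compound 1 or like compound 4, which would show how much of that step depends on the second methyl.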